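Adding a methoxy group to the lowest-reading compound of three

The source may hold more compounds than are shown below. What is called first, only, known or untested is meant among the compounds shown, and "the series" means these compounds.

In a functional assay on A549 cells (Homo sapiens) for cytotoxicity, read by MTT assay, with a stated time of 48 h (a lower number here means a stronger inhibitor, a higher number a weaker inhibitor), three compounds sharing one core have been measured. Compound 1 `O=C(O)CN1C(=O)/C(=C/c2nc3ccccc3n2Cc2ccc(Cl)cc2)SC1=S` gives 17500 nM, compound 3 `CCn1c(/C=C2\SC(=S)N(CC(=O)O)C2=O)nc2ccccc21` gives 9440 nM, and compound 2 `O=C(O)CN1C(=O)/C(=C/c2nc3ccccc3n2Cc2ccccc2F)SC1=S` gives 2670 nM, the lowest of the three numbers. Compound 4 `COc1ccc2nc(/C=C3\SC(=S)N(CC(=O)O)C3=O)n(Cc3ccccc3F)c2c1` differs from compound 2 by one change: methoxy in place of hydrogen on an aromatic carbon.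

Among the measured compounds shown here, no measured step touches that carbon. All three steps alter the group on a saturated chain carbon bound to an aromatic nitrogen: a 6.6-fold lower number from compound 1 to compound 2 (0.82 log units; beyond the scatter), a 3.5-fold higher number from compound 2 to compound 3 (0.55 log units; beyond the scatter) and a 1.9-fold lower number from compound 1 to compound 3 (0.27 log units; within the scatter). They bear on the new change only indirectly, by showing how far one substitution has moved the number in this small set, and they give no direction for it. A small step is therefore expected in this assay, and the estimate is a 1.1-fold higher number from compound 2 to compound 4 (0.05 log units; within the scatter). The expected value for compound 4 is about 3000 nM, with an estimated range of 1000 nM to 9000 nM.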

Compound 4, half-maximal inhibitory concentration: 36200 nM
Estimate against measurement, compound 4: 12-fold (1.08 log units) below; the whole stated range lies below it.
By their numbers in this assay, from the lowest: compound 2; then compounds 3 and 1 (each within the scatter of the next); then compound 4.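

In this assay, methoxy in place of hydrogen is the only change shown on the six-membered aromatic ring of carbon only, and it gives a 14-fold higher number from compound 2 to compound 4 (1.13 log units; beyond the scatter), a larger step than any of the three changes on the saturated chain carbon. This aromatic carbon therefore matters in this assay, and here the added methoxy weakens the compound, although this rests on a single pair of compounds. Nothing measured here speaks to why the number rises.

On these data alone, whether a hydroxyl group, an amine or a single fluorine on the same carbon would move the number as far remains open. So does whether methoxy would have a similar effect alongside the 4-chlorophenyl of compound 1 or the methyl of compound 3.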